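The source may report more compounds than this note shows. Statements on the series, on what has been measured and on what is new or still open speak of the compounds shown alone.

Compound 1 `COc1cc(-c2nccn2C)cc(OC)c1OC` gives > 100000 nM in a functional assay on MDA-MB-231 cells (Homo sapiens) for antiproliferative activity, read by MTT assay, with a stated time of 72 h; a lower number here means a stronger inhibitor, a higher number a weaker inhibitor.
Compound 2 `COc1cc(-c2nccn2S(=O)(=O)c2ccccc2)cc(OC)c1OC` gives > 100000 nM in this assay.
Compound 3 `COc1ccc(-n2ccnc2-c2cc(OC)c(OC)c(OC)c2)cc1[N+](=O)[O-]` gives 7500 nM in this assay.

For compound 1 the figure is not a number but (the limit of > 100000 nM in this assay, at which 2 of the 3 values shown sit). For compound 2 the figure is likewise only a limit of the assay. Within the data shown here, compound 3 is the one compound of the three with a numbered result, and its value sits well inside the working range of this assay. Among the measured compounds shown here, compound 1 therefore stands at the weak edge of what the assay can report, and no step between measured compounds that differ in a single place is available to say how large a change to expect from a single alteration.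

Compound 4 `COc1cccc(-n2ccnc2-c2cc(OC)c(OC)c(OC)c2)c1` differs from compound 1 in one place: 3-methoxyphenyl in place of methyl on an aromatic nitrogen. Because compound 1 gives only a limit, the step in this assay can be judged only from the side of the limit. Compound 4 is expected to reach a numbered value, with the step of an at least 6.6-fold lower number from compound 1 to compound 4 (0.82 log units; beyond the scatter) pointing toward stronger inhibition and beyond the usual scatter. The expected value for compound 4 in this assay is 15000 nM, within a range from 3000 nM to 80000 nM, with a real chance that the assay again reports only a limit.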

Compound 4, half-maximal inhibitory concentration: 18300 nM
Compound 4: the middle estimate sits 1.2-fold (0.09 log units) below what was measured; low and high end bracket the measured number.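

Swapping methyl for 3-methoxyphenyl on the aromatic nitrogen gives the first readable single change at this position: in this assay the swap produces an at least 5.4-fold lower number from compound 1 to compound 4 (0.73 log units; beyond the scatter). Among these compounds, the position therefore accepts a far larger group carrying a six-membered aromatic ring, and in this pair the larger group goes with stronger inhibition, something the earlier compounds alone could not show. The true size of the step remains unknown and can be read only as a minimum, because compound 1 gives a limit rather than a number: the limit of > 100000 nM in this assay, at which 2 of the 4 values shown sit.

From the compounds shown here alone, whether a plain phenyl, a benzyl group or a longer chain ending in an amine would do as well on this nitrogen remains open. The compounds shown also offer no single-place comparison that separates the aromatic ring from its methoxy group, so the share of each in the step is unknown.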